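Pyrazinyl to 2-Fluorophenyl: Solubility Expected to Fall

The source may report more compounds than this note shows. Statements on the series, on what has been measured and on what is new or still open speak of the compounds shown alone.

Compound 1, `CCCOc1ccc(C[C@@H](Cc2ccccc2)C(=O)O)cc1CNC(=O)c1ccc(-c2cccc(F)c2)cc1`, in a physicochemical assay for solubility, read by HPLC, in phosphate buffer, measured as thermodynamic solubility, with a stated time of 48 h, at pH 7.2; a higher number here means a more soluble compound, a lower number a less soluble compound: compound 1 gives < 1 ug/mL, a limit of the assay.
Compound 2, `CCCOc1ccc(C[C@@H](Cc2ccccc2)C(=O)O)cc1CNC(=O)c1ccc(-c2cnccn2)cc1`, in this assay: compound 2 gives 32.2 ug/mL.
Compound 3, `CCCOc1ccc(C[C@@H](Cc2ccccc2)C(=O)O)cc1CNC(=O)c1ccc(-c2ccccc2C)cc1`, in this assay: compound 3 gives < 1 ug/mL, a limit of the assay.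

Among the measured compounds shown here, compound 2 stands alone among the three: it holds the only number in this assay, while the other two values are limits (the limit of < 1 ug/mL in this assay, at which 2 of the 3 values shown sit). Compound 4, `CCCOc1ccc(C[C@@H](Cc2ccccc2)C(=O)O)cc1CNC(=O)c1ccc(-c2ccccc2F)cc1`, has not yet been measured. Its structural change from compound 2 is 2-fluorophenyl in place of pyrazin-2-yl on an aromatic carbon. For the measured compounds named here, two measured steps bear on this change. The first is an at least 32-fold lower number from compound 2 to compound 3 (1.50 log units; beyond the scatter), a large drop from the pyrazinyl analogue to a carbon-only ring. Going by the values given here, the second is an at least 32-fold higher number from compound 1 to compound 2 (1.50 log units; beyond the scatter), where a 3-fluorophenyl analogue sits at the limit and the pyrazinyl analogue is the only compound with a number. Compound 4 carries a fluorophenyl group, as compound 1 does, and a carbon-only ring, as compound 3 does. Because an at least 32-fold lower number from compound 2 to compound 3 (1.50 log units; beyond the scatter) and an at least 32-fold higher number from compound 1 to compound 2 (1.50 log units; beyond the scatter) both run large and in the same direction, compound 4 is expected to show a 64-fold lower number from compound 2 to compound 4 (1.81 log units; beyond the scatter). Compound 4 is therefore estimated at 0.5 ug/mL, in the range 0.1 ug/mL to 2 ug/mL, most likely reported only as a limit.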

Compound 4, solubility: < 1 ug/mL
Compound 4: only a limit was reported (the forecaster's own chance of this, stated with the estimate: 85%); the middle value lies beyond the limit too.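

In this assay, 2-fluorophenyl in place of pyrazin-2-yl, on this aromatic carbon para to a large group, brings an at least 32-fold lower number from compound 2 to compound 4 (1.50 log units; beyond the scatter). The steps from compound 1 to compound 4 and from compound 3 to compound 4 cannot be read, since each joins two limits of the assay. Three different carbon-only rings at this place now share one reading, while compound 2 alone holds a number: the limit of < 1 ug/mL in this assay, at which 3 of the 4 values shown sit.

The compounds shown leave open how far the three limits lie from the true values, and whether those values differ among themselves. They also leave open whether pyridin-2-yl, which has one ring nitrogen, or a phenyl ring carrying an amine or a carboxylic acid, would give a number in this assay.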